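Adding a Chloro Group: Expected Cytotoxicity of Compound 4

The source may hold more compounds than are shown below. What is called first, only, known or untested is meant among the compounds shown, and "the series" means these compounds.

Compound 1 `O[C@@H]1Cc2cc(OC(F)(F)F)ccc2N[C@H](c2ccccc2)C1`: in an ADME assay on THP-1 cells (Homo sapiens) for cytotoxicity, read by MTT assay, with a stated time of 72 h (on this read-out higher numbers stand for lower toxicity in this test and lower numbers for higher toxicity in this test), compound 1 gives 104000 nM.
Compound 2 `O[C@@H]1Cc2cc(Cl)ccc2N[C@H](c2ccccc2)C1`: in this assay compound 2 gives 188000 nM.
Compound 3 `O[C@@H]1Cc2cc(F)ccc2N[C@H](c2ccccc2)C1`: in this assay compound 3 gives > 300000 nM, which is a limit of the test and not a number.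

Compound 2 holds the higher of the two numbers shown, but the gap to compound 1 is small: a 1.8-fold higher number from compound 1 to compound 2 (0.26 log units; within the scatter). Compound 4 `O[C@@H]1Cc2cc(Cl)ccc2N[C@H](c2ccc(Cl)cc2)C1` differs from compound 2 by chloro in place of hydrogen on an aromatic carbon. Going by the values given here, no measured step makes this same change; the closest ones swap groups on the other aromatic ring: an at least 2.8-fold higher number from compound 1 to compound 3 (0.46 log units; beyond the scatter) and an at least 1.5-fold higher number from compound 2 to compound 3 (0.20 log units; that floor lies within the scatter), the latter resting on (the limit of > 300000 nM in this assay, at which 1 of the 3 values shown sits). Those steps are small or modest, so a step of at most similar size, with no clear direction, is expected here: a 1.3-fold lower number from compound 2 to compound 4 (0.13 log units; within the scatter). Compound 4 is therefore estimated at 140000 nM, with a range from 60000 nM to 300000 nM.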

Compound 4, half-maximal cytotoxic concentration: 49200 nM
Compound 4: middle estimate off by 2.8-fold (0.45 log units), on the high side; the measured number lies below the stated range.
By their numbers in this assay, from the lowest: compound 4; then compounds 1 and 2 (each within the scatter of the next). At a limit, above all of these: compound 3.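

Chloro in place of hydrogen on an aromatic carbon, para to a large group, gives a 3.8-fold lower number from compound 2 to compound 4 (0.58 log units; beyond the scatter) in this assay. Going by these compounds alone, the earlier steps only swapped groups on the other aromatic ring, so this is the first sign that this place, too, can move the number, here towards higher toxicity in this test. Nothing shown accounts for the size or direction of this step.

The compounds shown leave open whether a methoxy group or an amine at this place would move the number the same way. They also leave open whether the step would hold with trifluoromethoxy or fluoro on the other ring.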